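Swapping a pyrazole for a chlorinated phenyl on the core

The source may report more compounds than this note shows. Statements on the series, on what has been measured and on what is new or still open speak of the compounds shown alone.

Measured so far in a functional assay on BJAB cells (Homo sapiens) for antiproliferative activity, with a stated time of 4 days; a lower number here means that less compound is needed, a higher number that more compound is needed for the effect:
compound 1 `COc1ccc(-c2c(C)nn(-c3nc(-c4ccc(Cl)c(Cl)c4)c(SC(C)C)s3)c2C(=O)O)cc1`: 2100 nM
compound 2 `Cc1nn(-c2nc(-c3ccc(Cl)c(Cl)c3)c(SC(C)C)s2)c(C(=O)O)c1-c1cnn(C)c1`: 6800 nM
compound 3 `Cc1c(-c2cc(Cl)cc(Cl)c2)c(C(=O)O)nn1-c1nc(-c2ccncc2)c(SC(C)C)s1`: "not active" (no number reported)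

Among the compounds with values here, compound 2 stands highest of the two reported numbers; its nearest neighbour is compound 1, and the change a 3.2-fold higher number from compound 1 to compound 2 (0.51 log units; beyond the scatter) is the only one-place step available. Compound 4 `Cc1nn(-c2nc(-c3ccc(Cl)c(Cl)c3)c(SC(C)C)s2)c(C(=O)O)c1-c1cccc(Cl)c1C` differs from compound 2 in one place: 3-chloro-2-methylphenyl in place of 1-methyl-1H-pyrazol-4-yl on an aromatic carbon. Within the data shown here, the one step that bears on it shows that a six-membered carbon ring at this position gave a lower number than the pyrazole, so a modest drop is expected for compound 4, with the estimated step of a 2.7-fold lower number from compound 2 to compound 4 (0.43 log units; beyond the scatter). Compound 3, which also carries a chlorinated phenyl here but differs elsewhere, was not active, which adds uncertainty. For compound 4 the expected value is 2500 nM, within 800 nM to 8000 nM.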

Compound 4, half-maximal effective concentration: 5100 nM
Compound 4: middle estimate off by 2.0-fold (0.31 log units), on the low side; the range from low to high includes it.
By their numbers in this assay, from the lowest: compound 1; then compounds 4 and 2 (each within the scatter of the next).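

In this assay, 3-chloro-2-methylphenyl in place of 1-methyl-1H-pyrazol-4-yl gives a 1.3-fold lower number from compound 2 to compound 4 (0.12 log units; within the scatter), so these two different rings cannot be told apart at this position. In place of 4-methoxyphenyl, the same group gives a 2.4-fold higher number from compound 1 to compound 4 (0.39 log units; beyond the scatter), so among these three compounds, a six-membered carbon ring alone does not guarantee the number of compound 1; what the ring carries also counts. No available evidence explains these results. On these data alone, whether a simple amine or a longer chain at this position would fit this narrow range remains open. Compound 3 differs in more than one place, so its result cannot be assigned to this position.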